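The source may report more compounds than this note shows. Statements on the series, on what has been measured and on what is new or still open speak of the compounds shown alone.

Values in a functional assay on MCF7 cells (Homo sapiens) for cytotoxicity, read by MTT assay, with a stated time of 72 h; a lower number here means a stronger inhibitor, a higher number a weaker inhibitor:
- compound 1 `O=C1c2c[n+]([O-])c3ccccc3c2C(=O)c2c1c1ccccc1n2Cc1cn([C@H]2O[C@H](CO)[C@@H](O)[C@H]2O)nn1`: 1490 nM
- compound 2 `CN1CCN(CCCCn2c3c(c4ccccc42)C(=O)c2c[n+]([O-])c4ccccc4c2C3=O)CC1`: 100 nM
- compound 3 `O=C1c2c[n+]([O-])c3ccccc3c2C(=O)c2c1c1ccccc1n2Cc1cn([C@H]2C[C@H](O)[C@@H](CO)O2)nn1`: 530 nM

Compound 2 stands lowest of the three, clearly apart from both compound 3 and compound 1. Compound 4 `O=C1c2c[n+]([O-])c3ccccc3c2C(=O)c2c1c1ccccc1n2CCN1CCCCC1` has not yet been measured. Its change from compound 2 is piperidin-1-yl in place of 2-(4-methylpiperazin-1-yl)ethyl on a saturated chain carbon, two bonds along the chain from an aromatic nitrogen, with piperidin-1-yl in place of 2-(4-methylpiperazin-1-yl)ethyl on a saturated chain carbon, two bonds along the chain from an aromatic nitrogen. Within the data shown here, the only measured step, a 2.8-fold lower number from compound 1 to compound 3 (0.45 log units; beyond the scatter), lies in another substituent, so it offers only a loose guide to size. Since compound 2 has the lowest value, at 100 nM, some rise seems likely. The expected step is a 2.0-fold higher number from compound 2 to compound 4 (0.30 log units; within the scatter). Compound 4 is estimated at 200 nM, within a range of 60 nM to 700 nM.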

Compound 4, half-maximal inhibitory concentration: 620 nM
Compound 4: middle estimate off by 3.1-fold (0.49 log units), on the low side; low and high end bracket the measured number.
By their numbers in this assay, from the lowest: compound 2; then compounds 3 and 4 (each within the scatter of the next); then compound 1.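

In this assay, the group carried on the aromatic nitrogen clearly affects the read-out: 2-(piperidin-1-yl)ethyl in place of 4-(4-methylpiperazin-1-yl)butyl gives a 6.2-fold higher number from compound 2 to compound 4 (0.79 log units; beyond the scatter). Among these compounds, the one earlier step lay in another substituent, so this is the first sign that this position is sensitive to change. The change shortens the chain and swaps the ring together, and nothing available explains the rise. The compounds shown leave open whether chain or ring accounts for the step; a piperidin-1-yl on a butyl chain would separate the two.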